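The source may report more compounds than this note shows. Statements on the series, on what has been measured and on what is new or still open speak of the compounds shown alone.

Measured so far in a functional assay on HeLa cells (Homo sapiens) for antiproliferative activity, read by MTT assay, with a stated time of 48 h; a lower number here means a stronger inhibitor, a higher number a weaker inhibitor:
Compound 1 `COc1ccc(-c2cn3cc(C4=CCN(C(=O)C(C)(C)C)CC4)ccc3n2)cc1OC` gives 5480 nM.
Compound 2 `COc1ccc(-c2cn3cc(C4=CCN(C(=O)c5ccccc5)CC4)ccc3n2)cc1OC` gives 10200 nM.
Compound 3 `COc1ccc(-c2cn3cc(C4=CCN(S(=O)(=O)C5CCCCC5)CC4)ccc3n2)cc1OC` gives 9990 nM.

Among these three, compound 3 sits between the other two, yet both gaps fall within the scatter: a 1.8-fold higher number from compound 1 to compound 3 (0.26 log units; within the scatter) and a 1.0-fold lower number from compound 2 to compound 3 (0.01 log units; within the scatter). Compound 4 `COc1ccc(-c2cn3cc(C4=CCN(S(=O)(=O)c5ccccc5)CC4)ccc3n2)cc1OC` keeps the shared core and the sulfonamide of compound 3 and differs in one place: phenyl in place of cyclohexyl on a sulfonyl sulfur. Among the measured compounds shown here, the only measured step that resembles this one exchanges a tert-butyl for a phenyl on a carbonyl carbon, and it changed little: a 1.9-fold higher number from compound 1 to compound 2 (0.27 log units; within the scatter). A comparable exchange on the sulfonyl sulfur is therefore expected to shift this assay little, possibly a modest rise in the number, giving an expected step of a 1.2-fold higher number from compound 3 to compound 4 (0.08 log units; within the scatter). Compound 4 is estimated at 12000 nM, within a range from 5000 nM to 30000 nM.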

Compound 4, half-maximal inhibitory concentration: 12600 nM
The estimate for compound 4 lay 1.1-fold (0.02 log units) below the measured number; the range from low to high includes it.
By their numbers in this assay, from the lowest: compounds 1, 3, 2 and 4 (each within the scatter of the next, the first and the last beyond it).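

In this assay, a ring change on the sulfonyl sulfur, a 1.3-fold higher number from compound 3 to compound 4 (0.10 log units; within the scatter), does not separate cyclohexyl from phenyl at this position. Replacing benzoyl with phenylsulfonyl on the ring nitrogen, a 1.2-fold higher number from compound 2 to compound 4 (0.09 log units; within the scatter), likewise gives no clear change, whereas replacing (tert-butyl)carbonyl with phenylsulfonyl, a 2.3-fold higher number from compound 1 to compound 4 (0.36 log units; beyond the scatter), gives the first gap in this set beyond the scatter, though only a modest one. Nothing available explains that gap.

Going by these compounds, it remains open whether a methyl group or a longer chain on the sulfonyl sulfur would move the number. The same holds for a phenyl ring carrying an amine or a carboxylic acid.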